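Working notes: the step from compound 2 to compound 4

A few compounds are considered here, and "the series" means these few. Any claim that something is new, unique, unknown or untested is made for them only; others in the source may bear on it.

Measured in a physicochemical assay for solubility, in phosphate buffer, at pH 7.4; on this read-out higher numbers stand for higher solubility and lower numbers for lower solubility:
- compound 1 `CC(=O)N[C@@H]1CCC[C@H](C(=O)Nc2cc(-c3cnn4c3CCCC4)ccn2)C1`: 730000 nM
- compound 2 `CC(=O)N[C@@H]1CCC[C@H](C(=O)Nc2cc(-c3cnn4ccccc34)c(Cl)cn2)C1`: 45000 nM
- compound 3 `CC(=O)N[C@@H]1CCC[C@H](C(=O)Nc2cc(-c3cnn4c3CCC4)c(Cl)cn2)C1`: 160000 nM

Among these three, compound 2 has the lowest number, at 45000 nM. Not yet measured is compound 4 `CC(=O)N[C@@H]1CCC[C@H](C(=O)Nc2cc(-c3cnc4n3CCC4)c(Cl)cn2)C1`, which differs from compound 2 as follows: a group of 8 heavy atoms (6 carbon, 2 nitrogen; one five-membered non-aromatic ring with 1 hetero atom, one five-membered aromatic ring with 2 hetero atoms) in place of a group of 9 heavy atoms (7 carbon, 2 nitrogen; one five-membered aromatic ring with 2 hetero atoms, one six-membered aromatic ring with 1 hetero atom), on an aromatic carbon. The exchange lies on an aromatic carbon, ortho to a chloro group. Going by the values given here, one measured step bears on it: a 3.6-fold higher number from compound 2 to compound 3 (0.55 log units; beyond the scatter). That step is modest, and its entering group has the same counts but is not the same structure. A rise of similar size in this assay is therefore expected, and the estimated move is a 3.3-fold higher number from compound 2 to compound 4 (0.52 log units; beyond the scatter). For compound 4 the estimate is 150000 nM, with an expected range of 60000 nM to 400000 nM.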

Compound 4, solubility: 490000 nM
For compound 4 the middle estimate is 3.3-fold (0.51 log units) below the measured one, and the stated range ends below it.
By their numbers in this assay, from the lowest: compound 2; then compound 3; then compounds 4 and 1 (each within the scatter of the next).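

In this assay, going by these compounds alone, the exchange on this aromatic carbon, ortho to a chloro group, gives an 11-fold higher number from compound 2 to compound 4 (1.04 log units; beyond the scatter) and is the first large step at this position. Two entering groups with the same counts are not interchangeable here, as a 3.1-fold higher number from compound 3 to compound 4 (0.49 log units; beyond the scatter) shows at the same place on the core. Nothing measured in the data at hand accounts for either step.

Open, going by these compounds, is whether the entering group of compound 4 gives a similar rise with hydrogen in place of the chloro group. Also open, on these data alone, is how an amine or a carboxylic acid on its five-membered non-aromatic ring would read.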